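Swapping the ring on the shared core of compound 2

The compounds below may be only part of what the source reports. "The series", "measured", "known", "first", "only" and "open" are said of these compounds alone.

Going by the values given here, compound 2 `Cc1ccccc1-n1nc(C)c2c1NC(=O)[C@H](C)S[C@@H]2c1ccc(-c2cc3ccccc3o2)cc1` sits at the bottom of the two numbers measured so far: in an assay on isolated protein for agonist activity at Bile acid receptor (Homo sapiens), read by AlphaScreen, with a stated time of 30 min (a lower number here means a smaller maximal response, a higher number a larger maximal response), compound 2 reaches 17%. Among the compounds with values here, its closest neighbour is compound 1 `Cc1ccccc1-n1nc(C)c2c1NC(=O)[C@H](C)S[C@@H]2c1ccc(-c2ccoc2)cc1`, which in this assay gives 40%; the one measured step runs a number 23 percentage points lower from compound 1 to compound 2 (beyond the scatter). Compound 3 `COc1ccc(Oc2ccc([C@H]3S[C@@H](C)C(=O)Nc4c3c(C)nn4-c3ccccc3C)cc2)cc1` has not yet been tested. It differs from compound 2 in one place: 4-methoxyphenoxy in place of 1-benzofuran-2-yl on an aromatic carbon. Within the data shown here, no measured step covers an entering 4-methoxyphenoxy, so the single step from compound 1 to compound 2 offers only a loose guide: changing the group on that aromatic carbon moved the read-out by a modest amount, beyond the scatter, and a shift of similar size in either direction seems plausible here. Compound 3 is therefore expected to give about 30% in this assay, with a likely range from 10% to 60%, which would mean an estimated step of a number 13 percentage points higher from compound 2 to compound 3 (beyond the scatter).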

Compound 3, largest response reached (reported as efficacy), in percent of the reference or control that the assay uses: 70%
Beside the measured number, compound 3's estimate is 40 percentage points below it; the whole stated range lies below it.
By their numbers in this assay, from the lowest: compound 2; then compound 1; then compound 3.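

This position can carry a much larger response than the first two groups suggested: in this assay, putting 4-methoxyphenoxy in place of 1-benzofuran-2-yl gives a number 53 percentage points higher from compound 2 to compound 3 (beyond the scatter) and putting it in place of furan-3-yl gives a number 30 percentage points higher from compound 1 to compound 3 (beyond the scatter) on the same aromatic carbon. The step from compound 2 to compound 3 keeps the count of 9 heavy atoms in the group, so that count alone does not set the read-out at this position. The new group also differs in three ways at once, with an oxygen joining it to the ring, a single six-membered ring and a methoxy group at its far end.

Going by these compounds, whether plain phenoxy, 4-methoxyphenyl or a group ending in an amine or a carboxylic acid would reach a similar response remains open, so these three differences cannot yet be separated. Nothing available here accounts for the rise in response.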